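Aryl tail changes at the anilino ring of the core

A few compounds are considered here, and "the series" means these few. Any claim that something is new, unique, unknown or untested is made for them only; others in the source may bear on it.

Measured so far:
- compound 1 `CCc1ccc(-c2ccc(NC3=CC(=O)c4ncncc4C3=O)cc2)cc1`: 1600 nM
- compound 2 `O=C1C(Nc2ccc(C3CCCCC3)cc2)=CC(=O)c2ncncc21`: 500 nM
- compound 3 `O=C1C(Nc2ccc(-c3ccccn3)cc2)=CC(=O)c2ncncc21`: 2700 nM

In a functional assay on BXPC-3 cells (Homo sapiens) for cytotoxicity, read by MTT assay, with a stated time of 72 h (on this read-out higher numbers stand for weaker inhibition and lower numbers for stronger inhibition), compound 1 gives 1600 nM, the second highest of the three numbers. Its nearest neighbour is compound 3, with a 1.7-fold higher number from compound 1 to compound 3 (0.23 log units; within the scatter); its furthest is compound 2, with a 3.2-fold lower number from compound 1 to compound 2 (0.51 log units; beyond the scatter). Between those two, a 5.4-fold higher number from compound 2 to compound 3 (0.73 log units; beyond the scatter).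

Compound 4 `CN1CCN(c2ccc(NC3=CC(=O)c4ncncc4C3=O)cc2)CC1` is not yet measured in this assay. It differs from compound 1 in one place: 4-methylpiperazin-1-yl in place of 4-ethylphenyl on an aromatic carbon.

Among the measured compounds shown here, two measured steps bear on this change, both starting from compound 1 and both exchanging the 4-ethylphenyl for another ring on the same aromatic carbon. The move to a six-membered non-aromatic ring of carbon only, in compound 2, gave a modest lower number; the move to a six-membered heteroaromatic ring, in compound 3, gave a slightly higher number that stays within the scatter. For the measured compounds named here, the 4-methylpiperazin-1-yl ring is non-aromatic but carries two nitrogens, so neither step is a clean precedent, and no step in this set combines these features. The expectation for compound 4 is therefore a step of a 1.1-fold lower number from compound 1 to compound 4 (0.03 log units; within the scatter) in this assay, most likely not beyond the scatter in either direction, with a wide range. Compound 4 is estimated at 1500 nM, between 400 nM and 6000 nM.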

Compound 4, half-maximal inhibitory concentration: 900 nM
Beside the measured number, compound 4's estimate is 1.7-fold (0.22 log units) above it, within the range that was stated.
By their numbers in this assay, from the lowest: compounds 2, 4, 1 and 3 (each within the scatter of the next, the first and the last beyond it).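

In this assay the 4-methylpiperazin-1-yl tail cannot be told apart from the 4-ethylphenyl tail, at a 1.8-fold lower number from compound 1 to compound 4 (0.25 log units; within the scatter) and from the cyclohexyl tail, at a 1.8-fold higher number from compound 2 to compound 4 (0.26 log units; within the scatter) on this aromatic carbon. Among the compounds shown here, the one step from compound 4 that clears the scatter leads from the other nitrogen-bearing tail, at a 3.0-fold lower number from compound 3 to compound 4 (0.48 log units; beyond the scatter) and so ring nitrogen alone does not fix the number here: the non-aromatic rings of compound 2 and compound 4 lie within the scatter of each other, compound 3 lies beyond it from both, and compound 1, which lies within the scatter of compound 3 and of compound 4 alike, keeps the series from splitting cleanly into aromatic and non-aromatic tails. Nothing in hand gives a reason for these differences.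

Still open, on these data alone, is which part of the 4-methylpiperazin-1-yl ring matters, a question that a morpholin-4-yl, a piperidin-1-yl or an unsubstituted piperazin-1-yl tail on the same carbon would address. Also open, as far as these compounds go, is how a tail ending in a primary amine or a carboxylic acid would compare with these rings in this assay on the shared core.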